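Thiophen-2-yl for phenyl on the shared core

The source may report more compounds than this note shows. Statements on the series, on what has been measured and on what is new or still open speak of the compounds shown alone.

Three compounds of the series have numbers in an assay on cells for displacement of a labelled ligand from adenosine receptor A1 (Homo sapiens), with a stated time of 60 min, tested at 1 uM; a lower number here means less inhibition, a higher number more inhibition at the concentration tested (going by the name of the read-out). Compound 1 `CC1=C(C(=O)OC(C)C)C(c2ccccc2)N/C(=N/C#N)N1` gives 20% in this assay. Compound 2 `CCOC(=O)C1=C(C)N/C(=N\C#N)NC1c1ccco1` gives 27%, a number that lies within the scatter of compound 1, so no order between the two can be read. Compound 3 `CC1=C(C(=O)OC(C)C)C(C2CCCC2)NC(=O)N1` gives 1%, a number that lies beyond the scatter below compound 1. On the numbers shown, compound 1 thus stands second highest of three, close to compound 2 and clearly apart from compound 3.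

Compound 4 `CC1=C(C(=O)OC(C)C)C(c2cccs2)N/C(=N/C#N)N1` is not yet measured in this assay. It differs from compound 1 in one place: thiophen-2-yl in place of phenyl on a saturated ring carbon. Among the compounds with values here, no measured pair isolates this change, so its size is open. The expectation is a step from compound 1 to compound 4 of a number 5 percentage points higher from compound 1 to compound 4 (within the scatter), that is, none beyond the scatter, with a small rise not excluded. Compound 4 is therefore estimated at 25% in this assay, in a range from 10% to 42%.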

Compound 4, a percentage reported as inhibition, at one concentration (the size of the read-out at that concentration, not a potency): 31%
Compound 4: middle estimate off by 6 percentage points, on the low side; measured number inside the range.
By their numbers in this assay, from the lowest: compound 3; then compounds 1, 2 and 4 (each within the scatter of the next, the first and the last beyond it).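

In this assay, within the data shown here, thiophen-2-yl in place of phenyl on the saturated ring carbon gives a step of a number 11 percentage points higher from compound 1 to compound 4 (beyond the scatter), the first step that isolates a single change at this position. The number at this carbon therefore responds to an exchange of one aromatic ring for another, though only modestly, and the five-membered sulfur-containing ring is accepted here with no loss of inhibition at the tested concentration. Nothing at hand accounts for the step, which stands as an observation only.

Open, going by these compounds, is how other rings on this carbon would read, for example pyridin-3-yl, thiophen-3-yl or a benzyl group. Also open, on these data alone, is whether the same exchange gives a similar step with ethoxycarbonyl in place of isopropoxycarbonyl on the shared core.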